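Swapping Sulfur for Selenium on a Shared Core

This account rests on a few compounds, and the source may have more. Where it says the series, first, only, none or still open, it means among the compounds named here.

Measured compounds:
compound 1, `COc1ccc(CNc2nc([SeH])nc3ccccc23)cc1`: 71600 nM
compound 2, `Sc1nc(NCc2ccccc2)c2ccccc2n1`: 10100 nM

In a functional assay on HT-29 cells (Homo sapiens) for cytotoxicity, read by MTT assay, with a stated time of 72 h (on this read-out lower numbers stand for stronger inhibition of growth and higher numbers for weaker inhibition of growth), compound 2 gives 10100 nM, the lower of the two numbers seen, while compound 1 gives 71600 nM, a gap beyond the usual scatter. Compound 3, `[SeH]c1nc(NCc2ccccc2)c2ccccc2n1`, has not yet been measured; it differs from compound 2 by one selenium atom in place of one sulfur atom, on an aromatic carbon, one selenium atom in place of one sulfur atom on an aromatic carbon. Among the compounds with values here, no measured pair isolates this change, so its size is uncertain; compound 1 also carries selenium but differs elsewhere too. A modest step toward weaker inhibition is expected, a 1.6-fold higher number from compound 2 to compound 3 (0.20 log units; within the scatter). Compound 3 is estimated at 16000 nM, within 4000 nM to 60000 nM.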

Compound 3, concentration for 50% growth inhibition: 62200 nM
Estimate against measurement, compound 3: 3.9-fold (0.59 log units) below; the whole stated range lies below it.
By their numbers in this assay, from the lowest: compound 2; then compounds 3 and 1 (each within the scatter of the next).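

In this assay, placing selenium instead of sulfur on the aromatic carbon between two ring nitrogen atoms gives a 6.2-fold higher number from compound 2 to compound 3 (0.79 log units; beyond the scatter) and thus shows that this single atom matters at this position. Hydrogen in place of methoxy gives a 1.2-fold lower number from compound 1 to compound 3 (0.06 log units; within the scatter) here, so among these compounds the gap between compound 1 and compound 2 goes with the selenium rather than the methoxy. No measurement available here explains the selenium step. Still open, on these data alone, is how an amine or a hydroxyl would fare at this position. As far as these compounds go, whether methoxy is equally silent on the sulfur compound also remains open.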